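The compounds below may be only part of what the source reports. "The series", "measured", "known", "first", "only" and "open" are said of these compounds alone.

Compound 1 `N#Cc1c(-c2ccccc2)c(C#N)c(=O)n(/N=C/c2cn(-c3ccccc3)nc2-c2ccccc2)c1N`: in an ADME assay on HeLa cells (Homo sapiens) for cytotoxicity, read by MTT assay (on this read-out higher numbers stand for weaker inhibition and lower numbers for stronger inhibition), compound 1 gives > 200 ug/mL, which is a limit of the assay and not a number.
Compound 2 `N#Cc1c(-c2ccc(F)cc2)c(C#N)c(=O)n(/N=C/c2cn(-c3ccccc3)nc2-c2ccccc2)c1N`: in this assay compound 2 gives > 200 ug/mL, again only a limit.
Compound 3 `COc1cc(-c2c(C#N)c(N)n(/N=C/c3cn(-c4ccccc4)nc3-c3ccccc3)c(=O)c2C#N)cc(OC)c1OC`: in this assay compound 3 gives > 200 ug/mL, also a limit.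

Compound 3 therefore stands at the same limit as the other two, and no order among the three can be read. Compound 4 `N#Cc1c(-c2ccc(Br)cc2)c(C#N)c(=O)n(/N=C/c2cn(-c3ccccc3)nc2-c2ccccc2)c1N` has not yet been measured. The change made is 4-bromophenyl in place of 3,4,5-trimethoxyphenyl on an aromatic carbon. The measured steps around this position, a step that the two limits leave unreadable from compound 1 to compound 2, a step that the two limits leave unreadable from compound 1 to compound 3 and a step that the two limits leave unreadable from compound 2 to compound 3, are all of unreadable size, and the limit of > 200 ug/mL in this assay, at which 3 of the 3 values shown sit, shows why: every value sits at that limit. No step beyond the usual scatter is therefore expected in this assay. Compound 4 is expected at 200 ug/mL, within 100 ug/mL to 400 ug/mL, which is estimated as a number no higher from compound 3 to compound 4 (the limit leaves the size open).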

Compound 4, half-maximal inhibitory concentration: > 200 ug/mL
Compound 4 was reported as a limit (the forecaster's own chance of this, stated with the estimate: 85%); the middle value lies on the limit itself.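

No step among compound 1, compound 2, compound 3 and compound 4 can be read, because all four sit at one limit: the limit of > 200 ug/mL in this assay, at which 4 of the 4 values shown sit.

On these data alone, whether the groups on the aromatic carbon change the inhibition at all remains open, since the true values of all four compounds stay unknown.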